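A few compounds are considered here, and "the series" means these few. Any claim that something is new, unique, unknown or untested is made for them only; others in the source may bear on it.

Compound 1 `O=C(CCCCCCNc1c(Nc2ccccc2)c(=O)c1=O)NO`: 6000000 nM
Compound 2 `Cc1cccc([C@@H](C)Nc2c(NCCCCCC(=O)NO)c(=O)c2=O)c1`: 89000000 nM
Compound 3 `O=C(CCCCCNc1c(NC2CCCCC2)c(=O)c1=O)NO`: 91000000 nM

These values come from a physicochemical assay for solubility, read by HPLC, in phosphate buffer, with a stated time of 24 h, at pH 7.4, tested at 100 uM; on this read-out higher numbers stand for higher solubility and lower numbers for lower solubility. Compound 3 and compound 2 lie within the scatter of each other, and compound 1 lies lower, beyond the scatter.

Compound 4 `COc1ccc(Nc2c(NCCCCCC(=O)NO)c(=O)c2=O)cc1` is not yet measured. It has 4-methoxyphenyl in place of cyclohexyl on a nitrogen on an aromatic ring.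

Among the measured compounds shown here, with no measured step to draw on, the closest guide is compound 1, which also has a six-membered aromatic ring on that nitrogen and gives 6000000 nM. It differs from compound 4 elsewhere too, so this support is thin. A fall beyond the scatter is expected, with a 4.6-fold lower number from compound 3 to compound 4 (0.66 log units; beyond the scatter) as the estimated step. For compound 4 the estimated value is 20000000 nM, with an expected range of 6000000 nM to 60000000 nM.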

Compound 4, solubility: 3300000 nM
Compound 4: middle estimate off by 6.1-fold (0.78 log units), on the high side, outside the stated range (below it).
By their numbers in this assay, from the lowest: compounds 4 and 1 (each within the scatter of the next); then compounds 2 and 3 (each within the scatter of the next).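

In this assay, the nitrogen substituent now has its first measured single change: 4-methoxyphenyl in place of cyclohexyl gives a 28-fold lower number from compound 3 to compound 4 (1.44 log units; beyond the scatter). This position therefore moves the read-out well beyond the scatter, at least for this pair. No measurement shown explains this step.

Still open, from the compounds shown here alone, is whether the step follows the change of ring, the methoxy group, or both. A dimethylamino or carboxylic acid group in place of the methoxy group could help separate these readings.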